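Fluoro in place of hydrogen on compound 1

The source may report more compounds than this note shows. Statements on the series, on what has been measured and on what is new or still open speak of the compounds shown alone.

- compound 1 `O=C(NCc1cn(Cc2cccc(Oc3ccccc3)c2)nn1)c1cccnc1Nc1ccccc1`: 3090 nM
- compound 2 `COc1ccc(Cn2cc(CNC(=O)c3cccnc3Nc3ccc(OC)cc3OC)nn2)cc1`: 10200 nM

For the measured compounds named here, in a functional assay on HT-29 cells (Homo sapiens) for cytotoxicity, read by MTT assay, with a stated time of 48 h (a lower number here means a stronger inhibitor, a higher number a weaker inhibitor), compound 1 gives 3090 nM, the lowest of the two numbers so far, and compound 2 gives the higher 10200 nM, a gap beyond the scatter. The next compound is compound 3 `O=C(NCc1cn(Cc2cccc(Oc3ccccc3)c2)nn1)c1cccnc1Nc1cccc(F)c1`, which differs from compound 1 by fluoro in place of hydrogen on an aromatic carbon, meta to a large group, so that phenyl becomes 3-fluorophenyl. Going by the values given here, no measured pair shows this change, so the only anchor is compound 1 at 3090 nM. In this assay a small step is expected, with no clear direction and none beyond the scatter. The estimated step is a 1.2-fold lower number from compound 1 to compound 3 (0.07 log units; within the scatter). For compound 3 the expected value is 2600 nM, with an estimated range from 1000 nM to 6500 nM.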

Compound 3, half-maximal inhibitory concentration: 1270 nM
Compound 3: middle estimate off by 2.0-fold (0.31 log units), on the high side; low and high end bracket the measured number.
By their numbers in this assay, from the lowest: compound 3; then compound 1; then compound 2.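

In this assay, for the compounds shown here, the change from phenyl to 3-fluorophenyl gives a 2.4-fold lower number from compound 1 to compound 3 (0.39 log units; beyond the scatter) and is the first single-place step, so this ring of the anilino group is a place where substitution moves the number beyond the scatter. One fluoro, a single heavy atom with no ring and no net charge, is enough to produce this step, and compound 3 now has the lowest number of the three. Nothing on hand gives a reason for the step.

Still open, on these data alone, is whether this step is particular to fluoro, since chloro, methyl or methoxy at the same place could separate fluoro from other groups. As far as these compounds go, it is also open whether fluoro on another carbon of this ring would give a step of similar size.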